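The source may hold more compounds than are shown below. What is called first, only, known or untested is meant among the compounds shown, and "the series" means these compounds.

The measured compounds:
Compound 1, `O=C1O[C@H]([C@@H](O)Cn2cc(CNS(=O)(=O)c3ccc(Cl)cc3F)nn2)C(OCc2ccccc2)=C1OCc1ccccc1`, gives 21600 nM in a functional assay on HCT-116 cells (Homo sapiens) for antiproliferative activity, read by MTT assay, with a stated time of 72 h; on this read-out higher numbers stand for weaker inhibition and lower numbers for stronger inhibition.
Compound 2, `O=C1O/C(=C\Cn2cc(-c3ccc(Br)cc3)nn2)C(OCc2ccccc2)=C1OCc1ccccc1`, reaches only the limit of > 100000 nM in this assay.
Compound 3, `COc1ccccc1-c1cn(C/C=C2\OC(=O)C(OCc3ccccc3)=C2OCc2ccccc2)nn1`, likewise reaches only the limit of > 100000 nM in this assay.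

Among the compounds with values here, compound 1 holds the only number among the three values; the other two sit at the limit described by the limit of > 100000 nM in this assay, at which 2 of the 3 values shown sit, so the step that the two limits leave unreadable from compound 2 to compound 3 cannot be read. Compound 4, `CCCCCCCCCCc1cn(C[C@H](O)[C@H]2OC(=O)C(OCc3ccccc3)=C2OCc2ccccc2)nn1`, differs from compound 1 as follows: nonyl in place of ((4-chloro-2-fluorophenyl)sulfonyl)amino on a saturated chain carbon bound to an aromatic carbon. Within the data shown here, no measured step touches this change, since compounds 2 and 3 differ from compound 1 in more than one place, and what they show is only that their values lie at a limit. The expectation for compound 4 therefore rests on compound 1 alone, with no ground to expect a step beyond the scatter in this assay in either direction, though the uncertainty is wide. Compound 4 is estimated at 30000 nM, between 8000 nM and 120000 nM, and the expected step of a 1.4-fold higher number from compound 1 to compound 4 (0.14 log units; within the scatter) is taken as small.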

Compound 4, half-maximal inhibitory concentration: 28800 nM
The estimate for compound 4 lay 1.0-fold (0.02 log units) above the measured number; the measured number falls inside the stated range.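

In this assay, nonyl in place of ((4-chloro-2-fluorophenyl)sulfonyl)amino on a saturated chain carbon bound to an aromatic carbon gives a 1.3-fold higher number from compound 1 to compound 4 (0.12 log units; within the scatter). In this pair, the sulfonylamino group with its aromatic ring can therefore give way to a plain chain with no ring, hydrogen-bond donor or hydrogen-bond acceptor, and the two values remain indistinguishable, something that compounds 2 and 3, each differing from compound 1 in more than one place, could not show. Nothing given here explains this outcome. As far as these compounds go, whether an amine, a carboxylic acid or a longer chain at this place would keep the value within the scatter remains open. The step between compounds 2 and 3 still cannot be read: the limit of > 100000 nM in this assay, at which 2 of the 4 values shown sit.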